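Rhodanylidene chromene series: N-carboxymethyl on the bromo analogue

A few compounds are considered here, and "the series" means these few. Any claim that something is new, unique, unknown or untested is made for them only; others in the source may bear on it.

Going by the values given here, compound 2 `O=C1NC(=S)S/C1=C\C1=Cc2cc(Br)ccc2OC1` is the only member of this set with a measured number: in a functional assay on MOLT-4 cells (Homo sapiens) for antiproliferative activity, read by MTT assay, with a stated time of 72 h (a lower number here means a stronger inhibitor, a higher number a weaker inhibitor), compound 2 gives 38200 nM. Compound 1 `O=C(O)CN1C(=O)/C(=C/C2=Cc3ccccc3OC2)SC1=S` carries the carboxymethyl group on the ring nitrogen and lacks the bromine; in this assay compound 1 reaches only a limit, > 100000 nM, so no number is known for it. Thus the limit of > 100000 nM in this assay, at which 1 of the 2 values shown sits, is all that the carboxymethyl-bearing member contributes.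

Compound 3 `O=C(O)CN1C(=O)/C(=C/C2=Cc3cc(Br)ccc3OC2)SC1=S` is the bromo compound with the same change: carboxymethyl in place of hydrogen on an amide-type nitrogen in a ring. Among the compounds with values here, no direct step for this change has been measured. The expectation is a step weakening in this assay, a 2.4-fold higher number from compound 2 to compound 3 (0.37 log units; beyond the scatter), beyond the scatter, since compound 1 with the same nitrogen substituent sits at > 100000 nM. Compound 3 is therefore expected near 90000 nM, within a range from 30000 nM to 250000 nM, with a real chance that only a limit is reported.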

Compound 3, half-maximal inhibitory concentration: > 25000 nM
Compound 3 gave a limit, no number; the forecaster's own chance of this, stated with the estimate: 45%; the middle value does not contradict the limit.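

No step can be read from compound 3 to either neighbour: compound 3 and compound 1 each give only a limit in this assay, and compound 2 alone has a number. The compounds shown leave open how far carboxymethyl on the amide-type nitrogen, or bromo, shifts the read-out.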